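The source may hold more compounds than are shown below. What is called first, only, known or untested is meant among the compounds shown, and "the series" means these compounds.

Working notes on the difluoro series. In a functional assay on the whole organism with Mus musculus as the target, at a dose of 100 mg/kg by the intraperitoneal route (on this read-out higher numbers stand for more inhibition at the one dose given (going by the name of the read-out) and lower numbers for less inhibition), compound 1 `CN(C)C(=O)/C=C1\CCc2c(F)cc(F)cc21` gives 100% and compound 2 `NC(=O)/C=C1\CCc2c(F)cc(F)cc21` gives 100%; between them no change at the digits printed from compound 1 to compound 2 (within the scatter). Compound 3 `CCNC(=O)/C=C1\CCc2c(F)cc(F)cc21` gives 67% in this assay, the lowest of the three numbers, since a number 33 percentage points lower from compound 1 to compound 3 (beyond the scatter) and a number 33 percentage points lower from compound 2 to compound 3 (beyond the scatter).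

Compound 4 `CC(C)NC(=O)/C=C1\CCc2c(F)cc(F)cc21` differs from compound 3 by methyl in place of hydrogen on a saturated chain carbon bound to an amide-type nitrogen and a saturated chain carbon. Both steps that bear on it are the large falls on building out the amide-type nitrogen, from compound 2 to compound 3 and from compound 1 to compound 3. Going from ethylamino to isopropylamino is therefore expected to bring at most a modest further fall, or none beyond the scatter, in this assay, so a number 12 percentage points lower from compound 3 to compound 4 (beyond the scatter) is estimated. Compound 4 is expected to give 55% in this assay, with a range of 30% to 80%.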

Compound 4, a percentage reported as inhibition, in the whole organism at one dose (the size of the read-out at that dose, not a potency): 100%
The estimate for compound 4 lay 45 percentage points below the measured number, and the stated range ends below it.
By their numbers in this assay, from the lowest: compound 3; then compounds 1, 2 and 4 (each within the scatter of the next).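

Methyl in place of hydrogen on this saturated chain carbon restores the number in this assay, with a number 33 percentage points higher from compound 3 to compound 4 (beyond the scatter) as the step, so a larger group on the amide-type nitrogen does not by itself bring a fall. Isopropylamino matches the two other amides, with no change at the digits printed from compound 2 to compound 4 (within the scatter) and no change at the digits printed from compound 1 to compound 4 (within the scatter) in the two comparisons, which leaves compound 3 as the only one of the four set apart. Nothing on hand accounts for the ethylamino result.

On these data alone, whether a longer chain such as n-propyl or n-butyl on the nitrogen follows ethylamino or isopropylamino stays open. So does the effect of tert-butyl at this place.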